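A few compounds are considered here, and "the series" means these few. Any claim that something is new, unique, unknown or untested is made for them only; others in the source may bear on it.

In a functional assay on HepG2 cells (Homo sapiens) for cytotoxicity, with a stated time of 24 h (on this read-out higher numbers stand for weaker inhibition and lower numbers for stronger inhibition), three members of this series have been measured. Compound 1 `O=C(N/N=C/c1cc(I)cc(I)c1O)c1ccc(F)cc1` gives 12100 nM, and compound 2 `O=C(N/N=C/c1cc(I)cc(I)c1O)c1ccc([N+](=O)[O-])cc1` gives 24700 nM. Going by the values given here, the one step between them, a 2.0-fold higher number from compound 1 to compound 2 (0.31 log units; beyond the scatter), is the only measured step in the set. Compound 3 `COc1ccc(C(=O)N/N=C/c2cc(I)c(O)c(I)c2)cc1` stands apart: in this assay compound 3 reached only the limit > 100000 nM, which is a limit of the assay and not a number, as recorded in the limit of > 100000 nM in this assay, at which 1 of the 3 values shown sits.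

Compound 4 `O=C(N/N=C/c1cc(I)c(O)c(I)c1)c1ccc(Cl)cc1` differs from compound 3 in a single place: chloro in place of methoxy on an aromatic carbon. Among the compounds with values here, no measured step follows this exact exchange. Within the data shown here, the only step that bears on it, a 2.0-fold higher number from compound 1 to compound 2 (0.31 log units; beyond the scatter), also swaps one substituent for another on the aromatic carbon of the benzamide part, and it was modest. Among the measured compounds shown here, a change of similar or somewhat larger size is therefore expected here, and since compound 3 sits at the limit, a move toward a measurable number is the more likely direction, though no step in the set rules out another limit. Compound 4 is expected to reach 50000 nM, within 15000 nM to 150000 nM, which means an expected step of an at least 2.0-fold lower number from compound 3 to compound 4 (0.30 log units; that floor lies within the scatter).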

Compound 4, half-maximal inhibitory concentration: > 100000 nM
Compound 4: no number, only a limit; the forecaster's own chance of this, stated with the estimate: 35%; at least 2.0-fold (0.30 log units) between middle value and limit.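

In this assay compound 4 gives > 100000 nM, which is a limit of the assay and not a number. Compound 3 also stands at a limit, so no step from compound 3 to compound 4 can be read: the limit of > 100000 nM in this assay, at which 2 of the 4 values shown sit.

The compounds shown leave open whether chloro and methoxy on this aromatic carbon differ at all in this assay.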